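The source may report more compounds than this note shows. Statements on the series, on what has been measured and on what is new or still open speak of the compounds shown alone.

In a functional assay on KB cells (Homo sapiens) for antiproliferative activity, read by sulforhodamine B assay, with a stated time of 3 days (on this read-out higher numbers stand for an effect only at larger amounts of compound and lower numbers for an effect already at smaller amounts), compound 1, `CCC1=C(O)c2c(oc(-c3ccccc3)cc2=O)C(CC)(CC)C1=O`, has only hydrogen at the aromatic carbon that varies across this small set. Compound 1 gives > 236 uM, which is a limit of the assay and not a number. Compound 2, `CCCCc1ccc(-c2cc(=O)c3c(o2)C(CC)(CC)C(=O)C(CC)=C3O)cc1`, carries butyl there and gives 111 uM. Compound 3, `CCC1=C(O)c2c(oc(-c3ccc(OC)cc3)cc2=O)C(CC)(CC)C1=O`, carries methoxy and gives 17.7 uM, the lowest of the two true numbers, with compound 2 its nearest neighbour.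

Compound 4, `CCC1=C(O)c2c(oc(-c3ccc(SC)cc3)cc2=O)C(CC)(CC)C1=O`, has not yet been measured. It differs from compound 3 at one place: methylsulfanyl in place of methoxy on an aromatic carbon. This is methylsulfanyl in place of methoxy on an aromatic carbon, para to a large group.

For the measured compounds named here, no measured step makes this exact exchange, but three show that the group at this place matters. Adding butyl gave an at least 2.1-fold lower number from compound 1 to compound 2 (0.32 log units; beyond the scatter), and adding methoxy gave a large at least 13-fold lower number from compound 1 to compound 3 (1.12 log units; beyond the scatter). Exchanging butyl for methoxy gave a 6.3-fold lower number from compound 2 to compound 3 (0.80 log units; beyond the scatter). Methylsulfanyl is the same size as methoxy by heavy-atom count, so a change as large as that from compound 1 to compound 3 seems unlikely, yet the swap could still lose part of the gain. A small move towards a higher number in this assay is therefore expected, and the estimated step is a 1.7-fold higher number from compound 3 to compound 4 (0.23 log units; within the scatter). For compound 4 the expected value is 30 uM, within an estimated range of 9 uM to 100 uM.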

Compound 4, concentration for half-maximal effect: > 52.1 uM
Compound 4: only a limit was reported (the forecaster's own chance of this, stated with the estimate: 7%); middle value at least 1.7-fold (0.23 log units) from the limit.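

In this assay, the exchange at this place gives an at least 2.9-fold higher number from compound 3 to compound 4 (0.46 log units; beyond the scatter), so methoxy cannot be replaced by methylsulfanyl without a loss. The earlier steps shown here compared hydrogen, butyl and methoxy, which differ in heavy-atom count, so they could not show whether size alone set the result. This pair has the same counts of heavy atoms and hydrogen-bond acceptors and differs in exchanging oxygen for sulfur, yet the number still moves beyond the scatter, which shows that matching those counts is not enough to keep the result of compound 3. The steps from compound 1 and from compound 2 to compound 4 cannot be read, since compound 4 is reported only as a limit and not as a number: the limit of > 52.1 uM in this assay, at which 1 of the 4 values shown sits.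

On these data alone, how far compound 4 really lies from compound 3 therefore stays unknown, and so does its order relative to compound 2. As far as these compounds go, it also stays open whether oxygen at this place is what counts, which a hydroxyl or an ethoxy group in the same place could help to show, and whether a nitrogen-linked group such as dimethylamino would behave like methoxy or like methylsulfanyl.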